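Trifluoromethyl on the ring carbon of compound 1

The compounds below may be only part of what the source reports. "The series", "measured", "known", "first", "only" and "open" are said of these compounds alone.

Compound 1 `FC(F)(F)Oc1ccc(Oc2ccnc(N3CCC(NC(=S)Nc4cccnc4)CC3)c2)cc1` is the strongest of three measured compounds in an assay on membranes from brain for binding affinity to Lysophosphatidylserine lipase ABHD12 (Mus musculus), read by fluorescence, with a stated time of 20 min; a higher number here means a weaker inhibitor, a lower number a stronger inhibitor: compound 1 gives 410 nM. Compound 2 `S=C(Nc1cccnc1)NC1CCN(c2cc(OC3CCCCC3)ccn2)CC1` gives 3400 nM and compound 3 `S=C(Nc1cccnc1)NC1CCN(c2cc(OCC3CC3)ccn2)CC1` gives 4700 nM. The known steps are an 8.3-fold higher number from compound 1 to compound 2 (0.92 log units; beyond the scatter), an 11-fold higher number from compound 1 to compound 3 (1.06 log units; beyond the scatter) and a 1.4-fold higher number from compound 2 to compound 3 (0.14 log units; within the scatter), all of them exchanges of the group on the ring oxygen. Compound 4 `FC(F)(F)Oc1ccc(Oc2ccnc(N3CCC(NC(=S)Nc4cccnc4)CC3)c2C(F)(F)F)cc1` differs from compound 1 elsewhere: trifluoromethyl in place of hydrogen on an aromatic carbon. Going by the values given here, none of the measured steps touches that carbon, so no step bears directly on this change, and the expectation rests on compound 1 alone with a wide range. Compound 4 is expected to show a 1.5-fold higher number from compound 1 to compound 4 (0.17 log units; within the scatter), close to the scatter, in this assay. The estimate for compound 4 is 600 nM, between 150 nM and 2500 nM.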

Compound 4, half-maximal inhibitory concentration: 2800 nM
Beside the measured number, compound 4's estimate is 4.7-fold (0.67 log units) below it; the measured number lies above the stated range.
By their numbers in this assay, from the lowest: compound 1; then compounds 4, 2 and 3 (each within the scatter of the next).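

In this assay, placing trifluoromethyl in place of hydrogen on the aromatic carbon ortho to a 4-(trifluoromethoxy)phenoxy group gives a 6.8-fold higher number from compound 1 to compound 4 (0.83 log units; beyond the scatter). The number for compound 1 therefore responds to a change on this ring carbon, and not only to exchanges of the group on the ring oxygen. Nothing available explains this step. From the compounds shown here alone, whether a fluorine, a methyl or an amine on this carbon would stay closer to compound 1 remains open. So does whether trifluoromethyl here would give a similar step with cyclohexyl on the ring oxygen.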